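Aryl swap on the sulfonyl sulfur of compound 3

A few compounds are considered here, and "the series" means these few. Any claim that something is new, unique, unknown or untested is made for them only; others in the source may bear on it.

In a functional assay on HL-60 cells (Homo sapiens) for cytotoxicity, read by MTT assay (on this read-out higher numbers stand for weaker inhibition and lower numbers for stronger inhibition), compound 3 (`COc1ccc(S(=O)(=O)NC(C)C2=CC(=O)c3c(O)ccc(O)c3C2=O)c(OC)c1`) gives 500 nM and compound 1 (`COc1ccc(S(=O)(=O)NC(C2=CC(=O)c3c(O)ccc(O)c3C2=O)C(C)C)c(OC)c1`) gives 400 nM, so the two stand level within the scatter. Compound 2 (`Cc1ccccc1S(=O)(=O)NC(C)C1=CC(=O)c2c(O)ccc(O)c2C1=O`) stands clearly lower at 70 nM.

Compound 4 (`CC(NS(=O)(=O)c1cccc(Br)c1)C1=CC(=O)c2c(O)ccc(O)c2C1=O`) carries 3-bromophenyl in place of 2,4-dimethoxyphenyl on a sulfonyl sulfur.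

Among the compounds with values here, the one measured step at this place is a 7.1-fold higher number from compound 2 to compound 3 (0.85 log units; beyond the scatter), with 2,4-dimethoxyphenyl in place of 2-methylphenyl. The other step, a 1.3-fold higher number from compound 1 to compound 3 (0.10 log units; within the scatter), lies on the saturated chain carbon and offers no guide to this change. Within the data shown here, no measured compound here carries bromine, so the precedent is a single pair and the range stays wide.

Losing the 2,4-dimethoxyphenyl is expected to move the number down, part of the way towards the value of compound 2. The estimated change is a 3.8-fold lower number from compound 3 to compound 4 (0.59 log units; beyond the scatter). Compound 4 is expected at 130 nM, with an estimated range of 45 nM to 380 nM.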

Compound 4, half-maximal inhibitory concentration: 160 nM
Estimate against measurement, compound 4: 1.2-fold (0.09 log units) below; the range from low to high includes it.
By their numbers in this assay, from the lowest: compound 2; then compound 4; then compounds 1 and 3 (each within the scatter of the next).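

On the sulfonyl sulfur, a second aryl comparison in this assay shows that the high number of compound 3 is not tied to the 2-methylphenyl pair alone: 3-bromophenyl in place of 2,4-dimethoxyphenyl gives a lower number (a 3.1-fold lower number from compound 3 to compound 4 (0.49 log units; beyond the scatter)). The same change does not go all the way, since 3-bromophenyl in place of 2-methylphenyl still leaves a higher number (a 2.3-fold higher number from compound 2 to compound 4 (0.36 log units; beyond the scatter)), so these three aryl groups stand at three separate levels with the rest of the structure unchanged. No measurement shown here explains these differences between the aryl groups.

Open, from the compounds shown here alone, is whether 3-bromophenyl gives the same step with the isopropyl chain of compound 1 in place of the methyl. Also open, going by these compounds, is how this position reads with 2-bromophenyl, or with an aryl carrying an amine or a carboxylic acid.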